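Hydroxycyclohexyl to hydroxyethyl on the shared core

The source may report more compounds than this note shows. Statements on the series, on what has been measured and on what is new or still open speak of the compounds shown alone.

Compound 1 `COc1ccc(-c2c(-c3ccc(OC)cc3)n(Cc3ccccc3)c3ncn([C@@H]4CCCC[C@H]4O)c(=N)c23)cc1` gives only a limit in a functional assay on PC-3M cells (Homo sapiens) for antiproliferative activity, read by microscopy, with a stated time of 24 h (on this read-out higher numbers stand for weaker inhibition and lower numbers for stronger inhibition), > 20000 nM, so no single number stands for it. Compound 2 `N=c1c2c(-c3ccccc3)c(-c3ccccc3)n(CC3CC3)c2ncn1C1CCOCC1`, which carries other groups on the same core, gives 830 nM; 832 nM (2 entries) in this assay. Compound 3 `COc1ccc(-c2c(-c3ccc(OC)cc3)n(Cc3ccccc3)c3ncn(CCO)c(=N)c23)cc1` differs from compound 1 by 2-hydroxyethyl in place of 2-hydroxycyclohexyl on an aromatic nitrogen. Going by the values given here, no measured pair tracks this change, so no step beyond the scatter is expected, in either direction. Compound 3 is expected at 18000 nM, from 3000 nM to 60000 nM, with an expected step of an at least 1.1-fold lower number from compound 1 to compound 3 (0.04 log units; that floor lies within the scatter) and a fair chance of again only a limit.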

Compound 3, half-maximal inhibitory concentration: > 20000 nM
Compound 3 ended at the assay's limit; the forecaster's own chance of this, stated with the estimate: 65%; at least 1.1-fold (0.04 log units) between middle value and limit.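

Going by these compounds alone, compound 1 and compound 3 each give only a limit, so no step between them can be read. From the compounds shown here alone, whether 2-hydroxyethyl in place of 2-hydroxycyclohexyl on an aromatic nitrogen shifts the read-out at all stays open.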